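The source may hold more compounds than are shown below. What is called first, only, known or untested is meant among the compounds shown, and "the series" means these compounds.

In a functional assay on A549/CDDP cells (Homo sapiens) for antiproliferative activity, read by MTT assay, with a stated time of 72 h (a higher number here means a weaker inhibitor, a lower number a stronger inhibitor), compound 1 `Cc1nc(C)c(/C=C/C(=O)/C=C/c2ccc(O)cc2)nc1C` gives 4790 nM, and compound 2 `COc1ccc(/C=C/C(=O)/C=C/c2nc(C)c(C)nc2C)cc1` gives 3610 nM. These two values lie within the scatter of each other, so compound 2 stands level with compound 1 on the numbers available. Compound 3 `Cc1nc(C)c(/C=C/C(=O)/C=C/c2ccc(F)cc2)nc1C` keeps the core of compound 2 and differs from it in one group: fluoro in place of methoxy on an aromatic carbon. Within the data shown here, only one measured step bears on this change. It is a 1.3-fold lower number from compound 1 to compound 2 (0.12 log units; within the scatter), where methyl took the place of hydrogen on an oxygen on an aromatic ring, and it stayed within the scatter. Among the measured compounds shown here, no compound with fluoro has yet been measured, so the data favour no direction. The estimated step, a 1.1-fold higher number from compound 2 to compound 3 (0.04 log units; within the scatter), is expected to stay within the scatter as well. In this assay the expected value for compound 3 is 4000 nM, with an estimated range of 1800 nM to 9000 nM.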

Compound 3, half-maximal inhibitory concentration: 7440 nM
Beside the measured number, compound 3's estimate is 1.9-fold (0.27 log units) below it; the range from low to high includes it.
By their numbers in this assay, from the lowest: compounds 2, 1 and 3 (each within the scatter of the next, the first and the last beyond it).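

In this assay, among these compounds, this position now shows a first step beyond the scatter: fluoro in place of methoxy gives a 2.1-fold higher number from compound 2 to compound 3 (0.31 log units; beyond the scatter) as a modest change, whereas the earlier step from hydroxy to methoxy stayed within it. Fluoro in place of hydroxy on the same aromatic carbon gives a 1.6-fold higher number from compound 1 to compound 3 (0.19 log units; within the scatter) and stays within the scatter, so compound 1 and compound 3 stand level, and only the pair of compound 2 and compound 3 is separated. Nothing available explains this difference.

The three compounds leave open how chloro, an amine or a longer alkoxy chain on this aromatic carbon would read in this assay. They also leave open whether the modest separation holds for methoxy and fluoro on a different core.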